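Anilide to piperidine amide on the pyrrolidine series

This account rests on a few compounds, and the source may have more. Where it says the series, first, only, none or still open, it means among the compounds named here.

Of the compounds shown here, three of a shared core have been measured in an in vitro ADME assay on microsomes from liver (Mus musculus) for pharmacokinetics, read by LC-MS, with a stated time of 10 min, tested at 1 uM; on this read-out higher numbers stand for fast clearance and lower numbers for slow clearance. Compound 1 `CN1C[C@H](C(=O)Nc2cccc(F)c2)[C@@H](c2ccc(/C=C/C(=O)Nc3ccccc3N)cc2)C1` gives 56 mL/min/kg. Compound 2 `COc1cccc(NC(=O)[C@H]2CN(C)C[C@@H]2c2ccc(/C=C/C(=O)Nc3ccccc3N)cc2)c1` gives 65 mL/min/kg, and the step of a 1.2-fold higher number from compound 1 to compound 2 (0.06 log units; within the scatter) lies within the scatter. Compound 3 `CN1C[C@H](C(=O)Nc2ccc(F)cc2F)[C@@H](c2ccc(/C=C/C(=O)Nc3ccccc3N)cc2)C1` gives 27 mL/min/kg, the lowest of the three numbers; the steps of a 2.1-fold lower number from compound 1 to compound 3 (0.32 log units; beyond the scatter) and a 2.4-fold lower number from compound 2 to compound 3 (0.38 log units; beyond the scatter) are both modest but beyond the scatter, so compound 3 is the slowest-cleared compound seen so far.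

Compound 4 `CN1C[C@H](C(=O)N2CCCCC2)[C@@H](c2ccc(/C=C/C(=O)Nc3ccccc3N)cc2)C1` differs from compound 3 in one place: piperidin-1-yl in place of (2,4-difluorophenyl)amino on a carbonyl carbon. Going by the values given here, no measured step covers this kind of change; the steps seen so far only exchange one substituted phenyl for another on the amide-type nitrogen, and all of them stay modest. On that basis compound 4 is expected to sit near compound 3, with a small drift upward toward the rest of the series rather than a clear shift: an expected step of a 1.5-fold higher number from compound 3 to compound 4 (0.17 log units; within the scatter). The estimate for compound 4 in this assay is 40 mL/min/kg, expected within 20 mL/min/kg to 80 mL/min/kg.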

Compound 4, clearance: 42 mL/min/kg
Beside the measured number, compound 4's estimate is 1.1-fold (0.02 log units) below it, and the stated range covers the measured number.
By their numbers in this assay, from the lowest: compounds 3, 4, 1 and 2 (each within the scatter of the next, the first and the last beyond it).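

In this assay piperidin-1-yl on the carbonyl carbon stays within the scatter of all three arylamino amides, in each of the three steps (a 1.6-fold higher number from compound 3 to compound 4 (0.19 log units; within the scatter)) and (a 1.5-fold lower number from compound 2 to compound 4 (0.19 log units; within the scatter)) and (a 1.3-fold lower number from compound 1 to compound 4 (0.12 log units; within the scatter)). The earlier steps shown here only exchanged one substituted phenyl for another, whereas this change removes both the aromatic ring and the amide hydrogen at this position. Even so, compound 4 shows no step beyond the scatter to any other compound, although compound 3 and compound 2 do differ beyond it. No available evidence bears on the reason for this result.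

Still open, going by these compounds, is whether morpholin-4-yl or pyrrolidin-1-yl on the same carbonyl carbon would fall in this range. A cyclohexylamino group, which keeps the amide hydrogen without the aromatic ring, could separate the two parts of the change.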